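Pyridin-4-yl to pyrimidin-5-yl on the saturated ring carbon

This account rests on a few compounds, and the source may have more. Where it says the series, first, only, none or still open, it means among the compounds named here.

Compound 2 `CC[C@H](C)[C@H](N)CN(C(=O)[C@@H]1C[C@H]1c1ccncc1)c1ccc(-c2ccccc2)cc1` gives 1500 nM in a functional assay for agonist activity at G protein-coupled receptor 88 (Homo sapiens), read by HTRF and cAMP accumulation; a higher number here means that more compound is needed for the effect, a lower number that less compound is needed. Among the two numbers measured so far this is the lowest; its nearest neighbour is compound 1 `CC[C@H](C)[C@H](N)CN(C(=O)[C@@H]1C[C@H]1c1cccc(C#N)c1)c1ccc(-c2ccccc2)cc1`, which in this assay gives 1600 nM, and the two numbers lie within the scatter of each other, so no order between them can be read. Among the compounds with values here, the only step known in the set, a 1.1-fold lower number from compound 1 to compound 2 (0.03 log units; within the scatter), exchanged one six-membered aromatic ring for another on the saturated ring carbon and stayed within the scatter.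

Compound 3 `CC[C@H](C)[C@H](N)CN(C(=O)[C@@H]1C[C@H]1c1cncnc1)c1ccc(-c2ccccc2)cc1` differs from compound 2 by pyrimidin-5-yl in place of pyridin-4-yl on a saturated ring carbon. Within the data shown here, only the step from compound 1 to compound 2 bears on this, and it was small. Exchanging pyridin-4-yl for pyrimidin-5-yl, again one six-membered aromatic ring for another at the same place, is expected to behave alike: the step of a 1.1-fold higher number from compound 2 to compound 3 (0.05 log units; within the scatter) in this assay is expected to stay within the scatter, with no direction claimed. Compound 3 is therefore estimated at 1700 nM, with a range from 700 nM to 4200 nM.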

Compound 3, half-maximal effective concentration: 19000 nM
Compound 3: the middle estimate sits 11-fold (1.05 log units) below what was measured, outside the stated range (above it).
By their numbers in this assay, from the lowest: compounds 2 and 1 (each within the scatter of the next); then compound 3.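

In this assay, the aromatic ring on the saturated ring carbon of the three-membered ring is not interchangeable: a 13-fold higher number from compound 2 to compound 3 (1.10 log units; beyond the scatter) comes with pyrimidin-5-yl in place of pyridin-4-yl, and a 12-fold higher number from compound 1 to compound 3 (1.07 log units; beyond the scatter) comes with pyrimidin-5-yl in place of 3-cyanophenyl. The earlier step between 3-cyanophenyl and pyridin-4-yl stayed within the scatter, so exchanging one six-membered aromatic ring for another is not neutral in general at this place, even though pyridin-4-yl and pyrimidin-5-yl have the same count of heavy atoms and differ in carrying 1 against 2 hetero atoms and 1 against 2 hydrogen-bond acceptors. No measurement at hand offers an explanation for this large step.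

The exchange alters both the number of ring nitrogens and the point at which the aromatic ring is attached relative to them, and the compounds shown cannot separate the two; a pyridin-3-yl group at this place would bear on that question. Also open, going by these compounds, is how a plain phenyl, or a non-aromatic group such as an amine or a carboxylic acid, would behave at this carbon.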